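The source may report more compounds than this note shows. Statements on the series, on what has been measured and on what is new or still open speak of the compounds shown alone.

Of the compounds shown here, three have so far been measured in a functional assay on CAL-27 cells (Homo sapiens) for cytotoxicity, read by MTT assay, with a stated time of 72 h; on this read-out lower numbers stand for stronger inhibition and higher numbers for weaker inhibition. Compound 1 `Cc1cc(C)cc(CNC(=O)CN(CCCCCC(=O)Nc2ccccc2N)C(=O)c2cc(C)cc(C)c2)c1` gives 19300 nM. Compound 3 `Nc1ccccc1NC(=O)CCCCCN(CC(=O)NCc1ccccc1)C(=O)c1cccc2ccccc12` gives 11000 nM, a number within the scatter of that of compound 1, so these two cannot be told apart. Among the compounds with values here, compound 2 `Cc1cc(C)cc(C(=O)N(CC(=O)NCc2ccccc2)Cc2ccc(C(=O)Nc3cc(F)ccc3N)cc2)c1` gives 5720 nM, the only value beyond the scatter from compound 1; it is the stronger inhibitor of that pair, and compound 1 holds the highest number of the three.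

Compound 4 `Cc1ccc(CNC(=O)CN(CCCCCC(=O)Nc2ccccc2N)C(=O)c2cc(C)cc(C)c2)cc1` has not yet been measured. It differs from compound 1 in one place: 4-methylphenyl in place of 3,5-dimethylphenyl on a saturated chain carbon bound to an amide-type nitrogen. Within the data shown here, no measured pair shows the effect of such a change, so the data give no direct guide. Since the change leaves the ring type and the counted donors and acceptors unchanged, a step within the scatter is expected, with no clear direction. Compound 4 is therefore estimated at 16000 nM, with a range from 7000 nM to 40000 nM. The step of a 1.2-fold lower number from compound 1 to compound 4 (0.08 log units; within the scatter) is expected to be small.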

Compound 4, half-maximal inhibitory concentration: 18200 nM
Estimate against measurement, compound 4: 1.1-fold (0.06 log units) below, and the stated range covers the measured number.
By their numbers in this assay, from the lowest: compounds 2, 3, 4 and 1 (each within the scatter of the next, the first and the last beyond it).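

In this assay, 4-methylphenyl in place of 3,5-dimethylphenyl on a saturated chain carbon bound to an amide-type nitrogen gives a 1.1-fold lower number from compound 1 to compound 4 (0.03 log units; within the scatter), so the two compounds cannot be told apart. Within the data shown here, this is the first pair here that differs in one place, and it shows that at this position a group of 7 heavy atoms can replace one of 8, with the methyl pattern on the ring also altered, without a step beyond the scatter. No measured property of these groups is available to account for this result.

From the compounds shown here alone, only these two methyl-bearing rings can be compared at this position, so the effect of a methoxy group, a chlorine atom or an amine on the ring stays open. Going by these compounds, it also stays open whether the same change would give a similar step on a different core, such as that of compound 2.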